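Trimming the Alkyl Group: From Compound 3 to Compound 4

This account rests on a few compounds, and the source may have more. Where it says the series, first, only, none or still open, it means among the compounds named here.

- Compound 1 `CC(=O)Nc1cnc2[nH]c(=O)n([C@H]3CC[C@H](C(C)(C)C)CC3)c(=O)c2c1` gives 67000 nM
- Compound 2 `CC(=O)Nc1cnc2[nH]c(=O)n([C@H]3CC[C@H](C(C)C)CC3)c(=O)c2c1` gives 32000 nM
- Compound 3 `CC(=O)Nc1cnc2[nH]c(=O)n([C@H]3CC[C@@H](C(C)C)CC3)c(=O)c2c1` gives 16000 nM

In an ADME assay on L6 cells (Rattus norvegicus) for cytotoxicity, read by resazurin assay, with a stated time of 70 h (on this read-out higher numbers stand for an effect only at larger amounts of compound and lower numbers for an effect already at smaller amounts), compound 3 gives 16000 nM and lies within the scatter of compound 2 and under compound 1. Compound 4 `CC[C@H]1CC[C@@H](n2c(=O)[nH]c3ncc(NC(C)=O)cc3c2=O)CC1` differs from compound 3 thus: hydrogen in place of methyl on a saturated chain carbon bound to a saturated chain carbon and a saturated ring carbon with isopropyl becoming ethyl. The nearest measured parallel, also hydrogen in place of methyl, is a 2.1-fold lower number from compound 1 to compound 2 (0.32 log units; beyond the scatter) and it is modest. The other step, a 2.0-fold lower number from compound 2 to compound 3 (0.30 log units; within the scatter), involves no such replacement, given the fact that compounds 2 and 3 differ only in the configuration as drawn and so sets no size here. A modest move to a lower number is therefore expected, though it may stay within the scatter. The estimated change is a 1.5-fold lower number from compound 3 to compound 4 (0.16 log units; within the scatter) in all. Compound 4 is expected at 11000 nM with an estimated range from 4500 nM to 30000 nM.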

Compound 4, half-maximal effective concentration: 48000 nM
Compound 4: middle estimate off by 4.4-fold (0.64 log units), on the low side, and the stated range ends below it.
By their numbers in this assay, from the lowest: compounds 3, 2, 4 and 1 (each within the scatter of the next, the first and the last beyond it).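

Cutting isopropyl to ethyl on the saturated chain carbon gave a 3.0-fold higher number from compound 3 to compound 4 (0.48 log units; beyond the scatter), so the loss of a methyl here moved the number upward, which compound 2 had not suggested. In this assay, hydrogen in place of methyl therefore has no single direction across the compounds shown: the same change on two cores in this assay, a 2.1-fold lower number (0.32 log units; beyond the scatter) from compound 1 to compound 2 and a 3.0-fold higher number (0.48 log units; beyond the scatter) from compound 3 to compound 4, 6.3-fold (0.80 log units) apart, beyond the scatter of two such steps

As far as these compounds go, whether this difference follows the configuration as drawn or the chain that is cut stays open. Also open, from the compounds shown here alone, is how an amine or a carboxylic acid in place of ethyl would read in this assay.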